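Fluoro to Methoxy: Estimating the Cytotoxicity of Compound 4

This account rests on a few compounds, and the source may have more. Where it says the series, first, only, none or still open, it means among the compounds named here.

In a functional assay on HeLa cells (Homo sapiens) for cytotoxicity, read by MTT assay, with a stated time of 2 days, tested at 100 uM (a higher number here means a weaker effect of the compound at the concentration tested, a lower number a stronger effect), three compounds have been measured:
Compound 1 `COc1ccc(-c2cc(C(C)=O)c3[nH]c(-c4ccccc4)cc3c2)cc1` gives 21.1%.
Compound 2 `CC(=O)c1cc(-c2ccccc2)cc2cc(-c3ccc(F)cc3)[nH]c12` gives 68.3%.
Compound 3 `CC(=O)c1cc(-c2ccc(F)cc2)cc2cc(-c3ccc(F)cc3)[nH]c12` gives 9.31%.

Compound 3 has the lowest number of the three, meaning the strongest effect: compound 1 comes nearest, beyond the scatter, and compound 2 lies furthest away. Compound 4 `COc1ccc(-c2cc(C(C)=O)c3[nH]c(-c4ccc(F)cc4)cc3c2)cc1` is the next compound, and its difference from compound 3 is methoxy in place of fluoro on an aromatic carbon. Among the compounds with values here, only one measured step touches this position: a number 59 percentage points lower from compound 2 to compound 3 (beyond the scatter), where fluoro entered in place of hydrogen. Within the data shown here, compound 4 instead carries methoxy there, and the one measured compound with methoxy at this place, compound 1, sits close to compound 3. That pairing gives no sign that methoxy weakens the effect. The expected step is therefore small, a number 5.7 percentage points higher from compound 3 to compound 4 (within the scatter), and compound 4 is estimated at 15%, within a range from 5% to 40%.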

Compound 4, a percentage reported as activity, at one concentration (the size of the read-out at that concentration, not a potency): 20.6%
Compound 4: the middle estimate sits 5.6 percentage points below what was measured; the measured number falls inside the stated range.
By their numbers in this assay, from the lowest: compound 3; then compounds 4 and 1 (each within the scatter of the next); then compound 2.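

In this assay, methoxy in place of hydrogen at this position also strengthens the effect by a wide margin (a number 47.7 percentage points lower from compound 2 to compound 4 (beyond the scatter)), so the large gain here does not belong to fluoro alone. Fluoro still keeps a modest edge over methoxy at this position (a number 11.3 percentage points higher from compound 3 to compound 4 (beyond the scatter)). Fluoro in place of hydrogen at a second place, in a compound already carrying methoxy, gives no change that stands out from the scatter (a number 0.5 percentage points lower from compound 1 to compound 4 (within the scatter)), so the gain from this change depends on the core that carries it: the same change on two cores in this assay, a number 59 percentage points lower (beyond the scatter) from compound 2 to compound 3 and a number 0.5 percentage points lower (within the scatter) from compound 1 to compound 4, 58.5 percentage points apart, beyond the scatter of two such steps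

From the compounds shown here alone, whether an amine, a carboxylic acid or a longer chain such as ethoxy would keep the effect at this position remains open. These readings show only a stronger or weaker effect at the one concentration tested and leave open how the compounds compare at any other concentration.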